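A few compounds are considered here, and "the series" means these few. Any claim that something is new, unique, unknown or untested is made for them only; others in the source may bear on it.

Measured compounds in this series:

Compound 1, `O=C(Nc1cnn(-c2ccccc2)c1)c1cccc(NS(=O)(=O)c2ccc(Cl)cc2)c1`: 19300 nM
Compound 2, `Cc1ccc(-n2cc(NC(=O)c3cccc(NS(=O)(=O)c4ccc(Cl)cc4)c3)cn2)cc1`: 15600 nM
Compound 3, `O=C(Nc1cnn(-c2ccccc2)c1)c1ccc(NS(=O)(=O)c2ccccc2)cc1`: 87100 nM

All three numbers come from a functional assay on A549 cells (Homo sapiens) for inhibition, read by MTT assay, with a stated time of 48 h; on this read-out lower numbers stand for stronger inhibition and higher numbers for weaker inhibition. Compound 3 gives the highest number of the three; its nearest neighbour is compound 1, and its step to compound 2 is larger still. The cores of compound 1 and compound 3 differ in more than one place, and the difference between the two cores is not broken down here; their values alone show that compound 3 sits well above compound 1 in this assay.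

Compound 2 differs from compound 1 by methyl in place of hydrogen on an aromatic carbon, and the step it made was a 1.2-fold lower number from compound 1 to compound 2 (0.09 log units; within the scatter). Within the data shown here, compound 4, `Cc1ccc(-n2cc(NC(=O)c3ccc(NS(=O)(=O)c4ccccc4)cc3)cn2)cc1`, has not yet been measured; it differs from compound 3 by methyl in place of hydrogen on an aromatic carbon, the same change as the one from compound 1 to compound 2, at a place described in the same words. This change has been seen only once among the measured compounds.

For compound 4 the expected step is a 1.2-fold lower number from compound 3 to compound 4 (0.06 log units; within the scatter), which rests on the measured value of compound 3, 87100 nM, and on the step from compound 1 to compound 2, a 1.2-fold lower number from compound 1 to compound 2 (0.09 log units; within the scatter), which was within the scatter. Compound 4 is therefore estimated to give 75000 nM in this assay, with a likely range from 35000 nM to 160000 nM; with a single precedent the range is kept wide.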

Compound 4, half-maximal inhibitory concentration: 54700 nM
For compound 4 the middle estimate is 1.4-fold (0.14 log units) above the measured one; the measured number falls inside the stated range.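

In this assay, methyl in place of hydrogen on an aromatic carbon, here phenyl to 4-methylphenyl, gives a 1.6-fold lower number from compound 3 to compound 4 (0.20 log units; within the scatter), and the two steps seen so far agree: the same change on two cores in this assay, a 1.2-fold lower number (0.09 log units; within the scatter) from compound 1 to compound 2 and a 1.6-fold lower number (0.20 log units; within the scatter) from compound 3 to compound 4, 1.3-fold (0.11 log units) apart, within the scatter of two such steps. On these two cores, then, the change carries over in the sense that both steps stay within the scatter and neither core stands apart from the other. This does not show that the methyl group has any real effect on inhibition in this assay, and two small steps say nothing about how the change would behave on a core outside these two.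

The compounds shown leave open whether another group at the same place on the aromatic ring, such as an amine, a methoxy group or a carboxylic acid, would give a step beyond the scatter on either core. They also leave open which of the several differences between the core of compound 1 and the core of compound 3 goes with the gap between their values, as no compound shown separates those differences one at a time.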